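The source may hold more compounds than are shown below. What is called first, only, known or untested is meant among the compounds shown, and "the series" means these compounds.

Series notes. The shared core of compound 1 `Cc1ccc(-n2nc(-c3ccccc3)nc2CNc2ccc(C(=O)NO)cc2)cc1` carries a methyl group; in an assay on Sf9 cells for inhibition of protein deacetylase HDAC6 (Homo sapiens), read by fluorescence, with a stated time of 40 min (a lower number here means a stronger inhibitor, a higher number a weaker inhibitor), compound 1 gives 310 nM. Going by the values given here, compound 2 `COc1ccc(-n2nc(-c3ccccc3)nc2CNc2ccc(C(=O)NO)cc2)cc1` carries methoxy in place of methyl on an aromatic carbon, and in this assay compound 2 gives 127 nM, the only step so far beyond the scatter: a 2.4-fold lower number from compound 1 to compound 2 (0.39 log units; beyond the scatter). Compound 3 `O=C(NO)c1ccc(NCc2nc(-c3ccccc3Cl)nn2-c2ccccc2)cc1` instead carries 2-chlorophenyl in place of phenyl; in this assay compound 3 gives 185 nM, and the values of compound 1 and compound 2 both lie within the scatter of compound 3, so no order among the three can be read from these numbers.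

Compound 4 `O=C(NO)c1ccc(NCc2nc(-c3ccccc3)nn2-c2ccccc2)cc1` differs from compound 3 by hydrogen in place of chloro on an aromatic carbon. Among the compounds with values here, no measured step touches this position: the single step beyond the scatter, from compound 1 to compound 2, concerns a substituent on a different aromatic ring and does not bear on it. What the numbers of compound 1, compound 2 and compound 3 show is that the substitution pattern on these aryl rings moves this assay only modestly. The expectation for compound 4 is therefore a step of no clear direction, a 1.1-fold higher number from compound 3 to compound 4 (0.03 log units; within the scatter), within the scatter. Compound 4 is estimated at 200 nM, in the range 90 nM to 450 nM.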

Compound 4, half-maximal inhibitory concentration: 112 nM
Compound 4: middle estimate off by 1.8-fold (0.25 log units), on the high side; the range from low to high includes it.
By their numbers in this assay, from the lowest: compounds 4, 2, 3 and 1 (each within the scatter of the next, the first and the last beyond it).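

At the place ortho to a large group, the change from 2-chlorophenyl to phenyl gives a 1.7-fold lower number from compound 3 to compound 4 (0.22 log units; within the scatter) in this assay, so chloro at this position cannot be told apart from hydrogen on these numbers, and the position shows no demand for a substituent. On the other aromatic ring, hydrogen and methoxy likewise cannot be told apart, with a 1.1-fold lower number from compound 2 to compound 4 (0.05 log units; within the scatter), whereas hydrogen in place of methyl gives a 2.8-fold lower number from compound 1 to compound 4 (0.44 log units; beyond the scatter), so of the two substituents on that ring only methyl stands apart from hydrogen, and by a modest step. Nothing at hand offers an explanation for these steps.

The compounds shown leave open whether any group at the 2-chlorophenyl position would move the number beyond the scatter, since chloro is the only substituent shown there; an amine, a carboxylic acid or a longer chain such as propyl could answer that. Also open is whether the methyl step holds on a core that carries chloro at that position, as no compound shown combines the two.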